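Methoxy in Place of Cyano on a Shared Core

The source may hold more compounds than are shown below. What is called first, only, known or untested is meant among the compounds shown, and "the series" means these compounds.

Three compounds built on one core have been run in an assay on isolated protein for inhibition of Amine oxidase [flavin-containing] B (Homo sapiens), read by fluorescence and spectrophotometry, with a stated time of 20 min; on this read-out higher numbers stand for weaker inhibition and lower numbers for stronger inhibition. Compound 1 `O=C1/C(=C/c2ccccc2)Cc2cc(O)ccc21` gives 376 nM. Compound 2 `Cc1cccc(/C=C2\Cc3cc(O)ccc3C2=O)c1`, carrying a methyl group, gives 52 nM, and compound 3 `N#Cc1cccc(/C=C2\Cc3cc(O)ccc3C2=O)c1`, carrying a cyano group, gives 130 nM. Compound 3 thus stands second of the three, with a 2.5-fold higher number from compound 2 to compound 3 (0.40 log units; beyond the scatter) and a 2.9-fold lower number from compound 1 to compound 3 (0.46 log units; beyond the scatter). Compound 4 `COc1cccc(/C=C2\Cc3cc(O)ccc3C2=O)c1` differs from compound 3 by methoxy in place of cyano on an aromatic carbon. Among the compounds with values here, no measured step swaps a cyano group for a methoxy group. Within the data shown here, the steps that bear on it, a 7.2-fold lower number from compound 1 to compound 2 (0.86 log units; beyond the scatter) and a 2.9-fold lower number from compound 1 to compound 3 (0.46 log units; beyond the scatter), show that both groups placed at this carbon lowered the number, methyl more than cyano. Compound 4 is therefore expected to show a 1.9-fold lower number from compound 3 to compound 4 (0.27 log units; within the scatter). Compound 4 is estimated at 70 nM, within 30 nM to 200 nM.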

Compound 4, half-maximal inhibitory concentration: 471 nM
Compound 4: the middle estimate sits 6.7-fold (0.83 log units) below what was measured; the whole stated range lies below it.
By their numbers in this assay, from the lowest: compound 2; then compound 3; then compounds 1 and 4 (each within the scatter of the next).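

The earlier compounds shown here showed only groups that lowered the number at this aromatic carbon, but methoxy in place of hydrogen gives no change beyond the scatter, with a 1.3-fold higher number from compound 1 to compound 4 (0.10 log units; within the scatter), so a gain here does not follow from any group placed on this carbon. Methoxy also falls behind both other groups, with a 3.6-fold higher number from compound 3 to compound 4 (0.56 log units; beyond the scatter) and a 9.1-fold higher number from compound 2 to compound 4 (0.96 log units; beyond the scatter). The step from cyano to methoxy keeps the count of heavy atoms and of hydrogen-bond acceptors, so those counts do not separate the two groups.

The compounds shown offer no measurement that accounts for this difference. Going by these compounds, whether an amine, a chlorine atom or a longer chain on this carbon would read like methyl or like methoxy remains open.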